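Ring swap on the imidazole nitrogen: compound 3 to compound 4

The source may hold more compounds than are shown below. What is called first, only, known or untested is meant among the compounds shown, and "the series" means these compounds.

Three close analogues of the shared core carry different saturated rings on the aromatic nitrogen. Compound 1 `COc1ccc(CCc2nc3cc(-c4c(C)noc4C)ccc3n2[C@H]2CC[C@H](OC)CC2)cc1Cl` bears a 4-methoxycyclohexyl group and in an assay on isolated protein for inhibition of histone acetyltransferase p300 (Homo sapiens), read by AlphaLISA, with a stated time of 20 min (on this read-out lower numbers stand for stronger inhibition and higher numbers for weaker inhibition), compound 1 gives 97 nM. Compound 2 `COc1ccc(CCc2nc3cc(-c4c(C)noc4C)ccc3n2C2CCN(S(C)(=O)=O)CC2)cc1Cl` carries a 1-(methylsulfonyl)piperidin-4-yl group, and in this assay compound 2 gives 148 nM. Compound 3 `COc1ccc(CCc2nc3cc(-c4c(C)noc4C)ccc3n2[C@H]2C[C@H](O)C2)cc1Cl` carries a 3-hydroxycyclobutyl group, and in this assay compound 3 gives 155 nM. Compound 3 sits at the upper end of the three numbers, but a 1.0-fold higher number from compound 2 to compound 3 (0.02 log units; within the scatter) and a 1.6-fold higher number from compound 1 to compound 3 (0.20 log units; within the scatter) are both within the scatter, as is a 1.5-fold higher number from compound 1 to compound 2 (0.18 log units; within the scatter); the three rings so far are indistinguishable on this read-out.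

Compound 4 `COc1ccc(CCc2nc3cc(-c4c(C)noc4C)ccc3n2[C@H]2CC[C@H](C(F)(F)F)CC2)cc1Cl` introduces a fourth ring at the same place: 4-(trifluoromethyl)cyclohexyl in place of 3-hydroxycyclobutyl on an aromatic nitrogen. Going by the values given here, no measured step covers a trifluoromethyl group, so the only guidance is that three quite different rings on this nitrogen, from a small cyclobutyl with a donor to a six-membered ring without one, left the number essentially unchanged. The return to a six-membered carbocycle recalls compound 1 97 nM more than compound 3.

a 1.4-fold lower number from compound 3 to compound 4 (0.15 log units; within the scatter) is therefore expected to remain within the scatter. Compound 4 is estimated at 110 nM in this assay, with a range from 45 nM to 270 nM.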

Compound 4, half-maximal inhibitory concentration: 894 nM
Compound 4: the middle estimate sits 8.1-fold (0.91 log units) below what was measured, outside the stated range (above it).
By their numbers in this assay, from the lowest: compounds 1, 2 and 3 (each within the scatter of the next); then compound 4.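

In this assay this position on the aromatic nitrogen of the shared core proves not to be indifferent to the group it carries: a 5.8-fold higher number from compound 3 to compound 4 (0.76 log units; beyond the scatter) and a 6.0-fold higher number from compound 2 to compound 4 (0.78 log units; beyond the scatter) both lie beyond the scatter, while the steps among compounds 1, 2 and 3 all stayed within it. The most direct comparison is a 9.2-fold higher number from compound 1 to compound 4 (0.96 log units; beyond the scatter) with the cyclohexyl ring kept and only trifluoromethyl in place of methoxy on a saturated ring carbon, so a six-membered carbocycle at this place does not by itself keep the number near that of compound 1, and the substituent on that ring matters. Going by these compounds alone, nothing measured so far accounts for this rise.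

The compounds shown leave open whether the rise belongs to trifluoromethyl specifically or would also appear with another substituent at the same ring carbon, such as a methyl, a hydroxyl or a plain hydrogen. They also leave open whether an amine or a carboxylic acid on the cyclohexyl ring would stay with compounds 1, 2 and 3 or move towards compound 4.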